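Replacing the aryl amide of compound 3 with a methoxycarbonyl group

The compounds below may be only part of what the source reports. "The series", "measured", "known", "first", "only" and "open" are said of these compounds alone.

Three amide analogues sharing one core have been measured so far. In a functional assay on HUVEC cells (Homo sapiens) for inhibition (on this read-out higher numbers stand for weaker inhibition and lower numbers for stronger inhibition), compound 1 `COc1cc(/C=C/C(=O)c2cccc(NC(=O)c3ccco3)c2)ccc1O` gives 0.38 ug/mL, compound 2 `COc1cc(/C=C/C(=O)c2cccc(NC(=O)c3ccccc3)c2)ccc1O` gives 0.37 ug/mL, and compound 3 `COc1cc(/C=C/C(=O)c2cccc(NC(=O)c3cc(Cl)cc(Cl)c3)c2)ccc1O` gives 0.75 ug/mL. For the measured compounds named here, compound 3 therefore stands with the highest number of the three, although the step of a 2.0-fold higher number from compound 1 to compound 3 (0.30 log units; within the scatter) lies within the scatter and only the step of a 2.0-fold higher number from compound 2 to compound 3 (0.31 log units; beyond the scatter) is beyond it. The step of a 1.0-fold lower number from compound 1 to compound 2 (0.01 log units; within the scatter) shows that exchanging one aromatic group for another on the carbonyl carbon left the number essentially unchanged.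

Compound 4 `COC(=O)C(=O)Nc1cccc(C(=O)/C=C/c2ccc(O)c(OC)c2)c1` has not yet been measured. Compared with compound 3 it carries the following change: methoxycarbonyl in place of 3,5-dichlorophenyl on a carbonyl carbon. Going by the values given here, the measured steps that bear on this position all concern aromatic rings on the carbonyl carbon, and none of them moved the number by more than a modest amount; no measured compound carries a non-ring group at this position, so the data give no direct guide. On that basis no step beyond the scatter is expected, with the number most likely falling somewhere among the three measured values. Compound 4 is therefore expected to give 0.5 ug/mL, with a range from 0.2 ug/mL to 1.5 ug/mL. This estimate corresponds to an expected step of a 1.5-fold lower number from compound 3 to compound 4 (0.18 log units; within the scatter).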

Compound 4, half-maximal inhibitory concentration: 1.5 ug/mL
Beside the measured number, compound 4's estimate is 3.0-fold (0.48 log units) below it; the measured number falls inside the stated range.
By their numbers in this assay, from the lowest: compounds 2, 1, 3 and 4 (each within the scatter of the next, the first and the last beyond it).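

For the compounds shown here, compound 4 puts the first non-ring group on this carbonyl carbon, and in this assay the result depends on which ring it is set against. Methoxycarbonyl in place of phenyl gives (a 4.1-fold higher number from compound 2 to compound 4 (0.61 log units; beyond the scatter)) and in place of furan-2-yl gives (a 3.9-fold higher number from compound 1 to compound 4 (0.60 log units; beyond the scatter)), so both steps lie beyond the scatter and show, as the exchanges among the rings did not show for compound 1, that this position does not accept every group with the number unchanged; against 3,5-dichlorophenyl, however, the step (a 2.0-fold higher number from compound 3 to compound 4 (0.30 log units; within the scatter)) lies within the scatter, so compound 3 and compound 4 cannot be told apart. No measurement shown here accounts for this result.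

With only one non-ring group at this position, the compounds shown leave open whether the higher number goes with the absence of a ring or with methoxycarbonyl in particular. A methyl group, a carboxylic acid or a longer chain on the same carbonyl carbon, set beside a saturated ring such as cyclohexyl, would bear on that question.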